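This account rests on a few compounds, and the source may have more. Where it says the series, first, only, none or still open, it means among the compounds named here.

For the measured compounds named here, in a toxicity assay on Vero C1008 cells (Chlorocebus sabaeus) for cytotoxicity (a higher number here means that more compound is tolerated, a lower number that less compound is tolerated), compound 1 `C[C@@H](NC(=O)c1ccccc1Cl)c1cccc2ccccc12` gives 376000 nM, the only actual number so far. Compound 2 `Cc1cc(N)ccc1C(=O)N[C@H](C)c1cccc2ccccc12` gives only a limit of the assay, > 500000 nM. Going by the values given here, no step between measured compounds is available, so there is no measured size of change to draw on.

Compound 3 `Cc1ccsc1C(=O)N[C@H](C)c1cccc2ccccc12` keeps the shared core of compound 1 and puts 3-methylthiophen-2-yl in place of 2-chlorophenyl on a carbonyl carbon. In this assay no change beyond the usual scatter is expected from this swap, in either direction, and the starting point remains compound 1 at 376000 nM. The expected 1.1-fold higher number from compound 1 to compound 3 (0.03 log units; within the scatter) is therefore small. A result reported only as a limit would not be a surprise. For compound 3 the estimated value is 400000 nM, with an expected range from 200000 nM to 500000 nM.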

Compound 3, half-maximal cytotoxic concentration: > 500000 nM
Compound 3 was reported as a limit; the forecaster's own chance of this, stated with the estimate: 35%; middle value at least 1.2-fold (0.09 log units) from the limit.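

In this assay compound 3 gives > 500000 nM, which is a limit of the assay and not a number. With 3-methylthiophen-2-yl in place of 2-chlorophenyl on a carbonyl carbon, the series gains its first step, an at least 1.3-fold higher number from compound 1 to compound 3 (0.12 log units; that floor lies within the scatter), and only the floor of that step is known. This place therefore takes a five-membered aromatic ring with 1 hetero atom with no sign of a lower number, while the true size of the step stays hidden because the read-out ends at a single value: the limit of > 500000 nM in this assay, at which 2 of the 3 values shown sit.

As far as these compounds go, whether an amine or a carboxylic acid on the aromatic ring would bring the number down to a measurable value stays open. For the compounds shown here, compound 1 remains the only compound with an actual number, so no step of fully measured size exists yet.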